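The source may hold more compounds than are shown below. What is called first, only, known or untested is meant among the compounds shown, and "the series" means these compounds.

The shared core of compound 1 `Nc1ccccc1NC(=O)c1ccc(COc2ccc([N+](=O)[O-])cc2)cc1` carries a nitro group on a six-membered aromatic ring of carbon only. In a functional assay on HepG2 cells (Homo sapiens) for antiproliferative activity, read by CCK-8 assay, with a stated time of 72 h (a lower number here means a stronger inhibitor, a higher number a weaker inhibitor), compound 1 gives only a limit, > 32000 nM. Compound 2 `Nc1ccccc1NC(=O)/C=C/c1ccc(COc2ccccc2)cc1`, whose amide is joined through a double bond and whose outer ring bears no substituent, also reaches only a limit in this assay, > 32000 nM. Among the compounds with values here, compound 3 `Cc1ccc(OCc2ccc(C(=O)Nc3ccccc3N)cc2)cc1` gives 6590 nM in this assay, and the step of an at least 4.8-fold lower number from compound 1 to compound 3 (0.68 log units; beyond the scatter) is the only measured change on that ring.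

Compound 4 `Nc1ccccc1NC(=O)c1ccc(COc2ccc(F)cc2)cc1` differs from compound 1 in one place: fluoro in place of nitro on an aromatic carbon. Within the data shown here, the single step that bears on this exchange is an at least 4.8-fold lower number from compound 1 to compound 3 (0.68 log units; beyond the scatter), and its size is itself uncertain because the limit of > 32000 nM in this assay, at which 2 of the 3 values shown sit, hides how far compound 1 truly lies. Fluoro is a small group like methyl, so compound 4 is expected to move in the same direction, though with a step estimated at an at least 2.1-fold lower number from compound 1 to compound 4 (0.32 log units; beyond the scatter) that may fall short of that of compound 3. Compound 4 is estimated at 15000 nM, within a range from 4000 nM to 40000 nM.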

Compound 4, half-maximal inhibitory concentration: 3840 nM
Compound 4: middle estimate off by 3.9-fold (0.59 log units), on the high side; the measured number lies below the stated range.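

Replacing nitro on this ring with a second group, fluoro, also brings a measurable number in this assay, with an at least 8.3-fold lower number from compound 1 to compound 4 (0.92 log units; beyond the scatter). Fluoro and methyl are not separated at this position, with a 1.7-fold lower number from compound 3 to compound 4 (0.23 log units; within the scatter), so among compound 1, compound 3 and compound 4 the clear gap lies between nitro and the other two groups. How wide that gap is remains unknown for compound 1 because its value is only a limit: the limit of > 32000 nM in this assay, at which 2 of the 4 values shown sit.

The compounds shown leave open whether an amine, a carboxylic acid or a methoxy group on this same carbon would fall with fluoro and methyl or with nitro. Also open, on these data alone, is how the core of compound 1 behaves with no substituent on this ring.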